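Swapping Chlorines for Fluorines on the Weakest Binder

This account rests on a few compounds, and the source may have more. Where it says the series, first, only, none or still open, it means among the compounds named here.

Of the compounds shown here, three from this series have been tested in an assay on isolated protein for binding affinity to sphingosine 1-phosphate receptor 2 (Homo sapiens), read by surface plasmon resonance; on this read-out higher numbers stand for weaker binding and lower numbers for tighter binding. Compound 1 `Cc1c(Cc2ccccc2)c(NNC(=O)Nc2cc(Cl)nc(Cl)c2)nc2c1cnn2C` gives 870 nM, compound 3 `COc1ccc(-c2cc(NNC(=O)Nc3cc(Cl)nc(Cl)c3)nc3c2c(C)nn3C)cc1` gives 1020 nM, and compound 2 `Cn1ncc2c(-c3ccc(F)cc3)cc(NNC(=O)Nc3cc(Cl)cc(Cl)c3)nc21` gives 4980 nM. On these numbers compound 2 stands highest of the three, that is, it binds most weakly: its gap to compound 3 and its gap to compound 1 both lie beyond the usual scatter of repeated measurements.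

The next compound follows directly from compound 2. Compound 4 `Cn1ncc2c(-c3ccc(F)cc3)cc(NNC(=O)Nc3cc(F)cc(F)c3)nc21` keeps the whole of compound 2 except for one change: 3,5-difluorophenyl in place of 3,5-dichlorophenyl on an amide-type nitrogen. The two halogens on that ring are exchanged, nothing else moves.

Going by the values given here, no measured pair in this set shows what such an exchange does, so the expectation rests on compound 2 alone. Since compound 2 already stands at the weak end of the three in this assay, a modest shift in either direction would leave it there. The step from compound 2 to compound 4 is expected to be small, a 1.4-fold higher number from compound 2 to compound 4 (0.15 log units; within the scatter), most likely a slight loss of binding that may not exceed the scatter. Compound 4 is therefore estimated to give 7000 nM in this assay, within a range from 2500 nM to 20000 nM.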

Compound 4, dissociation constant: 3980 nM
Estimate against measurement, compound 4: 1.8-fold (0.25 log units) above; the range from low to high includes it.
By their numbers in this assay, from the lowest: compounds 1 and 3 (each within the scatter of the next); then compounds 4 and 2 (each within the scatter of the next).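

In this assay, going by these compounds alone, the exchange of 3,5-dichlorophenyl for 3,5-difluorophenyl on the amide-type nitrogen gives a 1.3-fold lower number from compound 2 to compound 4 (0.10 log units; within the scatter) and offers the first reading of a single change, as compounds 1, 2 and 3 all differ from one another in more than one place. With the rest of the structure held fixed, compound 2 and compound 4 read alike, so at this position and on this core, the assay does not tell the two pairs of halogens apart. Nothing in the data shown explains why these two compounds read alike.

Going by these compounds, whether this position responds to a larger change remains open: an unsubstituted phenyl, a 3,5-dimethoxyphenyl, or a ring carrying an amine or a carboxylic acid could each read differently from compound 2. On these data alone, it is also open whether the same exchange of chlorine for fluorine would leave binding as little altered on the core of compound 1 or that of compound 3, as this one pair speaks only for the core of compound 2.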